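A 2,3-dichlorophenyl swap in an antiproliferative series

A few compounds are considered here, and "the series" means these few. Any claim that something is new, unique, unknown or untested is made for them only; others in the source may bear on it.

Of the compounds shown here, two have been read in a functional assay on A549 cells (Homo sapiens) for antiproliferative activity, read by MTT assay, with a stated time of 72 h (on this read-out higher numbers stand for weaker inhibition and lower numbers for stronger inhibition), so far. Among the compounds with values here, compound 2 (`O=C(N/N=C/c1ccc(F)cc1)Nc1ccc(Oc2ccnc3[nH]ccc23)cc1`) gives 1430 nM as the only number available. Compound 1 (`O=C(N/N=C/c1cccc(Cl)c1Cl)Nc1ccc(Oc2ccnc3[nH]ccc23)c(F)c1`) is reported as "not active" (no number reported) with no number attached, so compound 2 has no second figure to be ranked against.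

Compound 3 (`O=C(N/N=C/c1cccc(Cl)c1Cl)Nc1ccc(Oc2ccnc3[nH]ccc23)cc1`) is still unmeasured. Its change from compound 2 is 2,3-dichlorophenyl in place of 4-fluorophenyl on a carbon with a double bond to nitrogen and amounts to 2,3-dichlorophenyl in place of 4-fluorophenyl on a carbon with a double bond to nitrogen. Within the data shown here, no measured pair isolates this change, so the size of the step has no direct precedent.

Compound 1 also carries the 2,3-dichlorophenyl group. The expectation leans toward weaker inhibition because compound 1 gives "not active" (no number reported) in this assay and this single entry is thin support. The estimated 2.2-fold higher number from compound 2 to compound 3 (0.35 log units; beyond the scatter) therefore runs toward weaker inhibition, though a much smaller change remains possible. For compound 3 the estimate is 3200 nM with an expected range from 800 nM to 12000 nM as the working figures.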

Compound 3, half-maximal inhibitory concentration: "not active" (no number reported)
The entry for compound 3 holds no number; there is nothing to compare the estimate with.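

In this assay, within the data shown here, compound 3 gives "not active" (no number reported) and so offers no number, and no step from compound 2 to it can be read. The compounds shown leave open how large the change from 4-fluorophenyl to 2,3-dichlorophenyl is in numerical terms. Nothing shown bears on the reason for this result.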